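The source may hold more compounds than are shown below. What is called first, only, known or untested is meant among the compounds shown, and "the series" means these compounds.

For the measured compounds named here, in a functional assay on HCT-116 cells (Homo sapiens), read by sulforhodamine B assay, with a stated time of 5 days (a higher number here means a weaker inhibitor of growth, a lower number a stronger inhibitor of growth), compound 1 (`OC[C@H]1O[C@@H](n2cc(F)c3c(-c4cccs4)ncnc32)[C@H](O)[C@@H]1O`) gives 9 nM, the lower of the two numbers measured so far. Compound 2 (`OC[C@H]1O[C@@H](n2cc(F)c3c(-c4cc[nH]c4)ncnc32)[C@H](O)[C@@H]1O`) gives 250 nM. Exchanging the thiophen-2-yl group for a 1H-pyrrol-3-yl group thus produces a large step, a 28-fold higher number from compound 1 to compound 2 (1.44 log units; beyond the scatter). Compound 3 (`OC[C@H]1O[C@@H](n2cc(Cl)c3c(-c4cccs4)ncnc32)[C@H](O)[C@@H]1O`) keeps the thiophen-2-yl group and changes another place: chloro in place of fluoro on an aromatic carbon. In words, it carries chloro in place of fluoro on an aromatic carbon. Going by the values given here, the only measured step concerns a different place, so it gives no direct measure of this exchange. Among the compounds with values here, it shows only that compound 3 retains the group whose replacement gave a 28-fold higher number from compound 1 to compound 2 (1.44 log units; beyond the scatter). No step beyond the scatter is therefore expected in this assay, and the estimated step is a 1.6-fold higher number from compound 1 to compound 3 (0.19 log units; within the scatter). For compound 3 the estimated value is 14 nM, with an expected range from 5 nM to 45 nM.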

Compound 3, concentration for 50% growth inhibition: 270 nM
Estimate against measurement, compound 3: 19-fold (1.29 log units) below, and the stated range ends below it.
By their numbers in this assay, from the lowest: compound 1; then compounds 2 and 3 (each within the scatter of the next).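

In this assay, for the compounds shown here, chloro in place of fluoro gives a 30-fold higher number from compound 1 to compound 3 (1.48 log units; beyond the scatter), so the place on the five-membered aromatic ring also governs the read-out, whereas the earlier compounds showed a large step only at the thiophen-2-yl group. This exchange replaces one heavy atom with one heavy atom, and the counts of rings, hydrogen-bond donors, hydrogen-bond acceptors and net charge stay the same, so a single-atom exchange at this place is enough for a large step. Nothing shown here explains why the step is so large.

The compounds shown leave open how hydrogen, bromo, methyl or nitrile would read at this place. They also leave open whether chloro in place of fluoro gives a similar step when the 1H-pyrrol-3-yl group is present.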